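The source may hold more compounds than are shown below. What is called first, only, known or untested is meant among the compounds shown, and "the series" means these compounds.

Working notes on the series.

Two compounds carry measured values in a functional assay (Cavia porcellus) with sulfonylurea receptors; K-ATP channels (Homo sapiens) as the target; on this read-out lower numbers stand for stronger inhibition and higher numbers for weaker inhibition. Compound 1 `CC(O)(C(=O)Nc1ccc(S(=O)(=O)c2ccccc2)c(C#N)c1)C(F)(F)F` gives 3800 nM in this assay and stands lowest of the two numbers. Going by the values given here, compound 2 `CC(O)(C(=O)Nc1ccc(C#N)c(Sc2ccccc2)c1)C(F)(F)F` gives 8300 nM in this assay, a higher number than compound 1 by a margin beyond the usual scatter; the two differ in more than one place, so no single step is drawn between them.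

Compound 3 `COc1cc(NC(=O)C(C)(O)C(F)(F)F)ccc1S(=O)(=O)c1ccccc1` remains to be measured in this assay. It differs from compound 1 by methoxy in place of cyano on an aromatic carbon, ortho to a phenylsulfonyl group and meta to a large group.

Among the compounds with values here, no measured pair isolates this change, so the expectation rests on the single measured anchor compound 1 alone. The nitrile is kept in both measured compounds, and its loss is expected to move the number upward by a 2.1-fold higher number from compound 1 to compound 3 (0.32 log units; beyond the scatter), toward weaker inhibition. Compound 3 is therefore estimated at 8000 nM in this assay, within a range of 2500 nM to 25000 nM.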

Compound 3, half-maximal inhibitory concentration: 5900 nM
The estimate for compound 3 lay 1.4-fold (0.13 log units) above the measured number; low and high end bracket the measured number.
By their numbers in this assay, from the lowest: compounds 1, 3 and 2 (each within the scatter of the next, the first and the last beyond it).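

Until now the nitrile stood in both measured compounds, so this aromatic carbon, ortho to a phenylsulfonyl group, had shown only one substituent. In this assay, methoxy in place of cyano reads as a 1.6-fold higher number from compound 1 to compound 3 (0.19 log units; within the scatter) and so does not separate the two groups: on this core the number does not depend on keeping the nitrile at this place, and a methoxy with the same count of 2 heavy atoms and 1 hydrogen-bond acceptor serves equally within the scatter. No data on hand explain this result.

From the compounds shown here alone, whether an amine, a carboxylic acid or a longer alkoxy chain on this carbon would stay in the same range remains open. Also open, going by these compounds, is whether methoxy in place of cyano reads the same on a core other than that of compound 1.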